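The compounds below may be only part of what the source reports. "The series", "measured", "known", "first", "only" and "open" are said of these compounds alone.

Three compounds share one core and differ only in the group on the chain carbon bound to an oxygen on a saturated carbon. Compound 1 `COc1cc2nc(N3CCC(OCC(C)(C)OC)CC3)nc(N)c2cc1OC` gives 1.14 nM in an assay on brain for displacement of a labelled ligand from Adrenergic receptor alpha-1 (Rattus norvegicus); on this read-out lower numbers stand for stronger inhibition and higher numbers for weaker inhibition. Compound 2 `COc1cc2nc(N3CCC(OCC(C)O)CC3)nc(N)c2cc1OC` gives 3.52 nM in this assay. Compound 3 `COc1cc2nc(N3CCC(OCC(O)c4ccccc4)CC3)nc(N)c2cc1OC` gives 0.15 nM in this assay and so has the lowest number of the three, the strongest binding seen so far: the step of a 7.6-fold lower number from compound 1 to compound 3 (0.88 log units; beyond the scatter) and the step of a 23-fold lower number from compound 2 to compound 3 (1.37 log units; beyond the scatter) both lie beyond the scatter.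

Compound 4 `COc1cc2nc(N3CCC(OCC(C)(O)c4ccccc4)CC3)nc(N)c2cc1OC` has not yet been measured. It differs from compound 3 by methyl in place of hydrogen on a saturated chain carbon bound to an aromatic carbon, an oxygen on a saturated carbon and a saturated chain carbon. The measured steps touch this change only indirectly. The step of a 3.1-fold higher number from compound 1 to compound 2 (0.49 log units; beyond the scatter) shows that stripping methyls from that chain carbon gave a modest rise, which points to a modest fall, or no change, when a methyl is added. The step of a 23-fold lower number from compound 2 to compound 3 (1.37 log units; beyond the scatter) shows that a phenyl on that carbon is worth far more than a methyl, so the phenyl already present in compound 3 is expected to carry most of the effect.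

Compound 4 is therefore expected to sit close to compound 3, with the estimated step of a 1.3-fold lower number from compound 3 to compound 4 (0.10 log units; within the scatter) in this assay lying near or within the scatter. The estimate for compound 4 in this assay is 0.12 nM, with a range from 0.04 nM to 0.4 nM.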

Compound 4, inhibition constant: 0.62 nM
Estimate against measurement, compound 4: 5.2-fold (0.71 log units) below; the whole stated range lies below it.
By their numbers in this assay, from the lowest: compound 3; then compounds 4 and 1 (each within the scatter of the next); then compound 2.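

In this assay, among the compounds shown here, the step of a 4.1-fold higher number from compound 3 to compound 4 (0.62 log units; beyond the scatter) gives the first direct reading of a methyl on this carbon, and it shows that changing hydroxy(phenyl)methyl to 1-hydroxy-1-phenylethyl weakens binding even though only one heavy atom is added. For the compounds shown here, the phenyl still counts in the presence of that methyl, as the step of a 5.7-fold lower number from compound 2 to compound 4 (0.75 log units; beyond the scatter) shows, although this gain is smaller than the one in the step of a 23-fold lower number from compound 2 to compound 3 (1.37 log units; beyond the scatter), where the phenyl replaces the methyl instead. The step of a 1.8-fold lower number from compound 1 to compound 4 (0.26 log units; within the scatter) stays within the scatter, so 1-hydroxy-1-phenylethyl and 1-methoxy-1-methylethyl cannot be told apart here, despite the difference between those two groups.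

No supporting measurement is available to explain why the added methyl weakens binding in this series. As far as these compounds go, it also remains open how this position would respond to an ethyl in place of the methyl, or to an amine in place of the hydroxyl on the same carbon that carries the phenyl.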